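This account rests on a few compounds, and the source may have more. Where it says the series, first, only, none or still open, it means among the compounds named here.

In a functional assay on PC-3 cells (Homo sapiens) for cytotoxicity, read by MTT assay, with a stated time of 72 h (on this read-out lower numbers stand for stronger inhibition and higher numbers for weaker inhibition), compound 1 `COc1ccc(C(CC(=O)N[C@@H](CC(C)C)B(O)O)NC(=O)c2ccccc2)cc1` gives 830 nM and compound 2 `COc1ccc([C@H](CC(=O)N[C@@H](CC(C)C)B(O)O)NC(=O)c2ccccc2)cc1` gives 1110 nM, so compound 2 stands within the scatter of compound 1, its only comparator. Compound 3 `COc1ccc([C@@H](CC(=O)N[C@@H](CC(C)C)B(O)O)NC(=O)c2ccccc2)cc1` differs from compound 2 as follows: the two compounds have the same atoms and bonds and differ only in configuration as drawn: 1 of 2 stereo elements differ; a stereocentre at a saturated chain carbon is drawn S in compound 2 and R in compound 3. Going by the values given here, the one measured step that bears on this is a 1.3-fold higher number from compound 1 to compound 2 (0.13 log units; within the scatter), and it goes with the fact that one of compounds 1 and 2 is drawn with a defined configuration and the other without, at the place where they differ. If compound 1 holds both configurations, that small step suggests the R form lies close to the S form, perhaps slightly lower, so no step beyond the scatter is expected in this assay. The expected step is a 1.6-fold lower number from compound 2 to compound 3 (0.20 log units; within the scatter). For compound 3 the estimate is 700 nM, with a range from 300 nM to 1500 nM.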

Compound 3, half-maximal inhibitory concentration: 230 nM
For compound 3 the middle estimate is 3.0-fold (0.48 log units) above the measured one; the whole stated range lies above it.
By their numbers in this assay, from the lowest: compound 3; then compounds 1 and 2 (each within the scatter of the next).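

The stereocentre at a saturated chain carbon matters in this assay: going from S to R gives a 4.8-fold lower number from compound 2 to compound 3 (0.68 log units; beyond the scatter), which the within-scatter pair of compound 1 and compound 2 could not reveal. With the centre undefined as the starting point, the change to R gives a 3.6-fold lower number from compound 1 to compound 3 (0.56 log units; beyond the scatter), so compound 3 has the lowest number of the three. The difference between compound 2 and compound 3 rests on a single change: the fact that compounds 2 and 3 differ only in the configuration as drawn

Open, going by these compounds, is whether R stays ahead of S when the methoxy group gives way to an amine or a carboxylic acid. Also open, on these data alone, is whether the same order holds in cell lines other than this one.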